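The source may hold more compounds than are shown below. What is called first, only, known or untested is meant among the compounds shown, and "the series" means these compounds.

Measured so far in a functional assay on CNE-2 cells (Homo sapiens) for antiproliferative activity, read by sulforhodamine B assay, with a stated time of 48 h; a lower number here means a stronger inhibitor, a higher number a weaker inhibitor:
- compound 1 `COc1cc(C=C(C(=O)/C=C/c2cccc(OC)c2OC)C(=O)/C=C/c2cccc(OC)c2OC)cc(Br)c1O`: 220 nM
- compound 2 `COc1cccc(/C=C/C(=O)C(=Cc2ccc(OC)c(OC)c2OC)C(=O)/C=C/c2cccc(OC)c2OC)c1OC`: 410 nM
- compound 3 `COc1ccc(OC)c(/C=C/C(=O)C(=Cc2ccc(O)c(OC)c2)C(=O)/C=C/c2cc(OC)ccc2OC)c1`: 340 nM

At 340 nM, compound 3 lies within the scatter of both other compounds, so the three values give it no separate rank in this assay.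

Next is compound 4 `COc1ccc(OC)c(/C=C/C(=O)C(=Cc2ccc(O)c(F)c2)C(=O)/C=C/c2cc(OC)ccc2OC)c1`, not yet measured. It differs from compound 3 by one change: fluoro in place of methoxy on an aromatic carbon. In words, fluoro replaces methoxy on an aromatic carbon, ortho to a hydroxy group and meta to a large group, turning 4-hydroxy-3-methoxyphenyl into 3-fluoro-4-hydroxyphenyl.

Among the measured compounds shown here, no measured step makes this exchange. The nearest evidence is a 1.9-fold higher number from compound 1 to compound 2 (0.27 log units; within the scatter), with 2,3,4-trimethoxyphenyl in place of 3-bromo-4-hydroxy-5-methoxyphenyl on a double-bonded chain carbon. That step alters the same aryl group, and a much larger part of it than the change here, yet stays within the scatter. For the measured compounds named here, it is only one step, so it supports a small expectation without fixing a direction.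

The expected step is a 1.1-fold lower number from compound 3 to compound 4 (0.05 log units; within the scatter), so no change beyond the scatter is expected. The estimate for compound 4 is 300 nM, with an expected range of 130 nM to 700 nM.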

Compound 4, half-maximal inhibitory concentration: 380 nM
The estimate for compound 4 lay 1.3-fold (0.10 log units) below the measured number; the range from low to high includes it.
By their numbers in this assay, from the lowest: compounds 1, 3, 4 and 2 (each within the scatter of the next).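

In this assay, among the compounds shown here, fluoro replacing methoxy on the aromatic carbon ortho to the hydroxy group gives a 1.1-fold higher number from compound 3 to compound 4 (0.05 log units; within the scatter) and is the first measured step confined to this one position. The step from compound 1 to compound 2 altered several places on the aryl group together, so it could not isolate this position; here, methoxy, with 2 heavy atoms and 1 hydrogen-bond acceptor, gives way to fluoro, with 1 heavy atom and no hydrogen-bond acceptor, and no change beyond the scatter results. No measured property of either group is available to explain this outcome.

Within these compounds, this position therefore tolerates the exchange of methoxy for fluoro while the hydroxy group and the rest of the structure stay fixed, but that is a single exchange and does not define a trend. As far as these compounds go, whether an amine, a carboxylic acid or a longer chain such as butoxy at this position would give a step beyond the scatter stays open, as does the effect of the same exchange when the hydroxy group is replaced by methoxy.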